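Series notes: benzylsulfanyl swap on the dihydropyrimidine amide

The compounds below may be only part of what the source reports. "The series", "measured", "known", "first", "only" and "open" are said of these compounds alone.

Compound 3 `CC1=C(C(=O)Nc2ccc([N+](=O)[O-])cc2)C(c2cccc([N+](=O)[O-])c2)N=C(SCc2ccccc2Cl)N1` gives 7.7% in a functional assay on the whole organism (artery, strain albino) with Rattus norvegicus as the target, with a stated time of 120 min, at a dose of 10 mg/kg by the oral route; a lower number here means less inhibition, a higher number more inhibition at the dose given (going by the name of the read-out). Compound 2 `CC1=C(C(=O)Nc2ccc([N+](=O)[O-])cc2)C(c2ccc(Br)cc2)N=C(SCc2ccccc2Cl)N1` gives 7.7%, and the step of no change at the digits printed from compound 2 to compound 3 (within the scatter) is flat. Compound 1 `CC1=C(C(=O)Nc2ccc(Br)cc2)C(c2ccc(Cl)cc2Cl)N=C(SCc2ccc(F)cc2)N1` gives 22.7%, so compound 3 stands level with compound 2 and beyond the scatter below compound 1, the only one of the three with a clearly higher read-out.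

Compound 4 `CC1=C(C(=O)Nc2ccc([N+](=O)[O-])cc2)C(c2cccc([N+](=O)[O-])c2)N=C(SCc2ccc(F)cc2)N1` is the next one to be measured. It carries the change (4-fluorophenyl in place of 2-chlorophenyl on a saturated chain carbon bound to a sulfur). Going by the values given here, no measured step bears on this place: the only step in hand, no change at the digits printed from compound 2 to compound 3 (within the scatter), concerns the saturated ring carbon and shows no change. Compound 1 does carry the 4-fluorobenzyl group and reads higher, but it differs from compound 3 at two further places, so its value alone cannot be tied to the benzyl group. With nothing in hand pointing either way, the expected step of a number 2.3 percentage points higher from compound 3 to compound 4 (within the scatter) is none beyond the scatter. Compound 4 is therefore estimated at 10%, within 0% to 25%.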

Compound 4, a percentage reported as inhibition, in the whole organism at one dose (the size of the read-out at that dose, not a potency): 13.4%
Beside the measured number, compound 4's estimate is 3.4 percentage points below it, and the stated range covers the measured number.
By their numbers in this assay, from the lowest: compounds 2, 3, 4 and 1 (each within the scatter of the next, the first and the last beyond it).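

Going by these compounds alone, the exchange of 2-chlorophenyl for 4-fluorophenyl on a saturated chain carbon bound to a sulfur gives the first reading at this place: in this assay the step is a number 5.7 percentage points higher from compound 3 to compound 4 (within the scatter) and does not separate the two compounds. This place thus accepts one halogen-bearing phenyl group in exchange for another, with the same heavy-atom count, without a difference beyond the scatter. Nothing in hand explains the size of this step.

Still open, going by these compounds, is whether this place can move the read-out beyond the scatter at all, which a methyl group or a longer alkyl chain on the sulfur, or an amine or a carboxylic acid on the phenyl ring, would test. Also open, on these data alone, is whether the same exchange reads alike with other groups on the shared core.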